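The source may hold more compounds than are shown below. What is called first, only, known or untested is meant among the compounds shown, and "the series" means these compounds.

Measured so far in a functional assay on HCT-116 cells (Homo sapiens) for antiproliferative activity, read by MTT assay, with a stated time of 24 h; a lower number here means a stronger inhibitor, a higher number a weaker inhibitor:
compound 1 `COc1ccc2c(=O)c(-c3cc(OC)c(OC)cc3OC)coc2c1` gives 9170 nM;
compound 2 `COc1cc(OC)c(-c2coc3cc(OCc4ccc(F)cc4)ccc3c2=O)cc1OC` gives 950 nM.

Compound 1 holds the highest of these two numbers, and its nearest neighbour is compound 2, which sits at a lower number. The untested compound 3 `COc1cc(OC)c(-c2coc3cc(OCc4ccccc4C)ccc3c2=O)cc1OC` differs from compound 1 by 2-methylphenyl in place of hydrogen on a saturated chain carbon bound to an oxygen on an aromatic ring. Among the measured compounds shown here, the only measured step that bears on this is a 9.7-fold lower number from compound 1 to compound 2 (0.98 log units; beyond the scatter), where a different substituted phenyl entered at the same place. A step of similar size toward a lower number is therefore expected in this assay, roughly a 7.6-fold lower number from compound 1 to compound 3 (0.88 log units; beyond the scatter). Compound 3 is estimated at 1200 nM, within a range from 400 nM to 4000 nM.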

Compound 3, half-maximal inhibitory concentration: 2900 nM
Estimate against measurement, compound 3: 2.4-fold (0.38 log units) below; the measured number falls inside the stated range.
By their numbers in this assay, from the lowest: compound 2; then compound 3; then compound 1.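

In this assay, a second substituted phenyl at this saturated chain carbon also lowers the number, with a 3.2-fold lower number from compound 1 to compound 3 (0.50 log units; beyond the scatter), so the gain is not tied to 4-fluorophenyl alone. The size of the gain does depend on the group that enters: 2-methylphenyl in place of 4-fluorophenyl gives a 3.1-fold higher number from compound 2 to compound 3 (0.48 log units; beyond the scatter). No measurement at hand explains this difference. The compounds shown leave open whether the fluorine or the methyl matters more. Going by these compounds, what a plain unsubstituted phenyl, or a chain ending in an amine, would do at this place also remains open.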